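The source may hold more compounds than are shown below. What is called first, only, known or untested is meant among the compounds shown, and "the series" means these compounds.

Compound 1 `CCn1c(=O)/c(=C2\Sc3ccccc3N2C)s/c1=C\c1ccncc1Nc1ccccc1F` gives 360 nM in a functional assay on PC-3 cells (Homo sapiens) for inhibition; a lower number here means a stronger inhibitor, a higher number a weaker inhibitor.
Compound 2 `CCn1c(=O)/c(=C2\Sc3ccc(C)cc3N2C)s/c1=C\c1ccncc1Nc1ccccc1Cl` gives 500 nM in this assay.
Compound 3 `CCn1c(=O)/c(=C2\Sc3ccc(C)cc3N2C)s/c1=C\c1ccncc1Nc1ccccc1C` gives 330 nM in this assay.

Compound 3 shows the lowest of the three numbers, but its gaps to compound 1 and to compound 2 both lie within the scatter, so none of the three can be set apart from the others on these data.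

Compound 4 `CCn1c(=O)/c(=C2\Sc3ccc(C)cc3N2C)s/c1=C\c1ccncc1Nc1ccccc1F` has not yet been measured. It differs from compound 3 by fluoro in place of methyl on an aromatic carbon. Going by the values given here, no measured pair shows exactly this exchange. The closest measured step, a 1.5-fold lower number from compound 2 to compound 3 (0.18 log units; within the scatter), exchanges one group for another at the same place and stays within the scatter. The fluoro group is carried by compound 1, which also differs from compound 3 in a second place; compound 1 gives 360 nM. Compound 3 gives 330 nM. These two numbers lie within the scatter of each other. Taken together, these observations suggest that exchanging methyl for fluoro at this place changes little in this assay.

Compound 4 is therefore expected to give 380 nM, with a range from 200 nM to 720 nM. The expected step of a 1.2-fold higher number from compound 3 to compound 4 (0.06 log units; within the scatter) stays within the scatter.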

Compound 4, half-maximal inhibitory concentration: 70 nM
For compound 4 the middle estimate is 5.4-fold (0.73 log units) above the measured one, and the stated range ends above it.
By their numbers in this assay, from the lowest: compound 4; then compounds 3, 1 and 2 (each within the scatter of the next).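

In this assay, the group on the six-membered aromatic ring of carbon only, ortho to a large group, turns out to matter: fluoro gives a 4.7-fold lower number from compound 3 to compound 4 (0.67 log units; beyond the scatter) when it replaces methyl and a 7.1-fold lower number from compound 2 to compound 4 (0.85 log units; beyond the scatter) when it replaces chloro, whereas chloro and methyl at this place had stayed within the scatter of each other. The methyl on the shared core also counts, since placing it on an aromatic carbon in place of hydrogen gives a 5.1-fold lower number from compound 1 to compound 4 (0.71 log units; beyond the scatter) while the fluoro stays in place, so among these compounds the low number appears only where fluoro and that methyl occur together. Nothing measured here accounts for these steps.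

From the compounds shown here alone, how a plain hydrogen, a methoxy group or an amine at the place of the fluoro would compare stays open, so it cannot yet be said whether fluoro is unusual or chloro and methyl are the exceptions. Also open, going by these compounds, is whether the methyl on the core would give a similar step with chloro or methyl on the other ring, and whether an ethyl group there would do the same.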